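A second methyl on the tetrahydroisoquinoline ring carbon

The source may hold more compounds than are shown below. What is called first, only, known or untested is meant among the compounds shown, and "the series" means these compounds.

Of the compounds shown here, three sharing one core have been measured. Compound 1 `CC(C(=O)N1CC2CC2C1)N1CCN(S(=O)(=O)c2ccc(C(C)(C)C)cc2)CC1` in an ADME assay on HepG2 cells (Homo sapiens) for inhibition, with a stated time of 48 h (on this read-out higher numbers stand for an effect only at larger amounts of compound and lower numbers for an effect already at smaller amounts), gives > 40000 nM, which is a limit of the assay and not a number. Compound 2 `CC(C(=O)N(C)Cc1ccccc1)N1CCN(S(=O)(=O)c2ccc(C(C)(C)C)cc2)CC1` gives > 40000 nM, likewise only a limit. Among the compounds with values here, compound 3 `CC(C(=O)N1CCc2ccccc2C1C)N1CCN(S(=O)(=O)c2ccc(C(C)(C)C)cc2)CC1` gives 28000 nM, the only real number among the three; the two others sit at the limit of > 40000 nM in this assay, at which 2 of the 3 values shown sit. The change from compound 1 to compound 2 is a step that the two limits leave unreadable from compound 1 to compound 2. The two steps leading to compound 3 are an at least 1.4-fold lower number from compound 1 to compound 3 (0.15 log units; that floor lies within the scatter) and an at least 1.4-fold lower number from compound 2 to compound 3 (0.15 log units; that floor lies within the scatter), both with a floor that lies within the usual scatter.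

Compound 4 `CC(C(=O)N1CCc2ccccc2C1(C)C)N1CCN(S(=O)(=O)c2ccc(C(C)(C)C)cc2)CC1` differs from compound 3 by methyl in place of hydrogen on a saturated ring carbon. Within the data shown here, no measured step adds a methyl on a saturated ring carbon, so none bears directly on this change; the steps into compound 3 only show that replacing the whole amine portion moved the read-out modestly at best. A step no larger than the scatter is therefore expected, a 1.1-fold higher number from compound 3 to compound 4 (0.03 log units; within the scatter), in no preferred direction. For compound 4 a value of 30000 nM is estimated, between 12000 nM and 80000 nM, with a real chance that the assay again reports only a limit.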

Compound 4, half-maximal effective concentration: 31000 nM
Compound 4: the middle estimate sits 1.0-fold (0.01 log units) below what was measured, and the stated range covers the measured number.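

In this assay, within the data shown here, methyl in place of hydrogen on this saturated ring carbon gives a 1.1-fold higher number from compound 3 to compound 4 (0.04 log units; within the scatter), the first step on the shared core that joins two real numbers. This position, next to the ring nitrogen, therefore takes the added methyl with no shift in the read-out that can be told from the scatter. Compound 1 and compound 2 remain limits of the assay and not numbers: the limit of > 40000 nM in this assay, at which 2 of the 4 values shown sit.

The compounds shown leave open whether a different group on this ring carbon, such as ethyl, a hydroxyl or an amine, would leave the read-out equally unmoved. They also leave open whether a change elsewhere on the shared core, such as a carboxylic acid or a trifluoromethyl in place of the tert-butyl group, would move it.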